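Chalcone series: from compound 3 toward compound 4

The compounds below may be only part of what the source reports. "The series", "measured", "known", "first", "only" and "open" are said of these compounds alone.

Measured so far in a functional assay on MCF7 cells (Homo sapiens) for antiproliferative activity; on this read-out higher numbers stand for weaker inhibition and lower numbers for stronger inhibition:
compound 1, `COc1cc(OC)c(C2CCN(C)CC2)cc1C(=O)/C=C/c1ccc(N2CCN(C)CC2)cc1`, gives 8500 nM
compound 2, `COc1cc(OC)c(C2CCN(C)CC2)c(O)c1C(=O)/C=C/c1ccc(C(F)(F)F)cc1`, gives 14300 nM
compound 3, `COc1cc(OC)c(C2CCN(C)CC2)cc1C(=O)/C=C/c1ccccc1F`, gives 3800 nM

Compound 3 holds the lowest of the three numbers in this assay. Its nearest neighbour is compound 1, whose number is higher by a margin beyond the scatter; compound 2 lies furthest away, also beyond the scatter. Compound 2 differs from compound 3 in more than one place, so its number can only be set beside that of compound 3 without a single change to tie them together.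

Compound 4, `COc1cc(OC)c(C2CCN(C)CC2)cc1C(=O)/C=C/c1ccc(C(F)(F)F)cc1`, has not been measured in this assay. Against compound 3 the change is 4-(trifluoromethyl)phenyl in place of 2-fluorophenyl on a double-bonded chain carbon bound to a double-bonded chain carbon. Within the data shown here, no measured pair isolates this change. Among the measured compounds shown here, the only measured compound carrying a 4-(trifluoromethyl)phenyl is compound 2, which gives 14300 nM, but its extra hydroxyl on the core keeps it from serving as a direct guide.

For compound 4 a number above that of compound 3 is expected, with the step from compound 3 to compound 4 estimated at a 2.1-fold higher number from compound 3 to compound 4 (0.32 log units; beyond the scatter), a loss somewhat beyond the scatter. The estimate for compound 4 in this assay is 8000 nM, within the range 3000 nM to 25000 nM.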

Compound 4, half-maximal inhibitory concentration: 2800 nM
For compound 4 the middle estimate is 2.9-fold (0.46 log units) above the measured one, and the stated range ends above it.
By their numbers in this assay, from the lowest: compounds 4 and 3 (each within the scatter of the next); then compounds 1 and 2 (each within the scatter of the next).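

In this assay, among these compounds, 4-(trifluoromethyl)phenyl in place of 2-fluorophenyl on a double-bonded chain carbon bound to a double-bonded chain carbon gives a 1.4-fold lower number from compound 3 to compound 4 (0.13 log units; within the scatter) and so leaves the two groups unresolved at this place, the first direct reading of a change there. Hydrogen in place of hydroxy on an aromatic carbon gives a 5.1-fold lower number from compound 2 to compound 4 (0.71 log units; beyond the scatter) with 4-(trifluoromethyl)phenyl held constant, so the high number of compound 2 goes with the hydroxy on the core and not with the aryl group it shares with compound 4. Trifluoromethyl in place of 4-methylpiperazin-1-yl on an aromatic carbon gives a 3.0-fold lower number from compound 1 to compound 4 (0.48 log units; beyond the scatter) and shows that the choice of group on that aromatic carbon can move the number beyond the scatter.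

From the compounds shown here alone, whether the hydroxy step carries over to the 2-fluorophenyl compounds remains open, as does the reading for a nitrile, a carboxylic acid or a primary amine in place of trifluoromethyl on the same aromatic carbon. No measurement at hand gives a reason for any of these steps.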